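From phenyl to a five-membered ring on the carbonyl

The source may report more compounds than this note shows. Statements on the series, on what has been measured and on what is new or still open speak of the compounds shown alone.

Compound 1 `O=C(CSCc1nc2cc([N+](=O)[O-])ccc2[nH]1)c1ccccc1` gives 16100 nM in a functional assay on HepG2 cells (Homo sapiens) for cytotoxicity, read by MTT assay, with a stated time of 48 h (a lower number here means a stronger inhibitor, a higher number a weaker inhibitor), and holds the higher of the two numerical values in the series. Compound 2 `CCOC(=O)c1c(NC(=O)CSCc2nc3cc([N+](=O)[O-])ccc3[nH]2)sc2c1CCCCC2` reads lower at 7390 nM in this assay and the gap lies beyond the scatter. Compound 3 `O=C(CSCc1nc2cc([N+](=O)[O-])ccc2[nH]1)NNC(=S)Nc1ccccc1` stands at > 100000 nM as a limit of the assay and not a number. Compound 4 `CC1=NN(C(=O)CSCc2nc3cc([N+](=O)[O-])ccc3[nH]2)C(=O)C1` remains unmeasured. Its change from compound 1 is a group of 7 heavy atoms (4 carbon, 2 nitrogen, 1 oxygen; one five-membered non-aromatic ring with 2 hetero atoms) in place of a group of 6 heavy atoms (6 carbon; one six-membered aromatic ring of carbon only), on a carbonyl carbon with a group holding one five-membered non-aromatic ring with 2 hetero atoms in place of phenyl, on a carbonyl carbon. For the measured compounds named here, no measured pair shows this replacement, so the estimated step of a 1.2-fold higher number from compound 1 to compound 4 (0.09 log units; within the scatter) is expected to stay within the scatter in this assay with a slight lean toward a higher number. Compound 4 is expected at 20000 nM with an estimated range of 6000 nM to 70000 nM in this series.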

Compound 4, half-maximal inhibitory concentration: 7330 nM
Compound 4: the middle estimate sits 2.7-fold (0.44 log units) above what was measured, and the stated range covers the measured number.
By their numbers in this assay, from the lowest: compounds 4 and 2 (each within the scatter of the next); then compound 1. At a limit, above all of these: compound 3.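

Putting a group with one five-membered non-aromatic ring with 2 hetero atoms in place of phenyl, on a carbonyl carbon, gives a 2.2-fold lower number from compound 1 to compound 4 (0.34 log units; beyond the scatter) in this assay. For the compounds shown here, this is the first step read at this place, and it shows that phenyl can leave without the number rising. No measurement at hand accounts for the step.

As far as these compounds go, whether the ring itself or its 2 hydrogen-bond acceptors go with the lower number stays open. So does what a cyclopentyl group, an amine or a carboxylic acid on this carbonyl carbon would give.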